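The compounds below may be only part of what the source reports. "The series", "measured", "known", "first", "only" and "open" are said of these compounds alone.

In a functional assay on 786-0 cells (Homo sapiens) for inhibition, read by sulforhodamine B assay, with a stated time of 48 h, tested at 100 uM (on this read-out higher numbers stand for a weaker effect at the one concentration tested and lower numbers for a stronger effect), compound 1 `O=C(Nc1cccc(-n2cc(-c3ccncc3)c(-c3cc(O)cc(Cl)c3)n2)c1)Nc1ccc(Cl)c(C(F)(F)F)c1` gives -50%. For the measured compounds named here, its close relative compound 2 `O=C(Nc1cccc(-n2cc(-c3ccncc3)c(-c3cc(O)cc(Cl)c3)n2)c1)Nc1ccc(Cl)c(Cl)c1` gives -58% in this assay, and the step between them, a number 8 percentage points lower from compound 1 to compound 2 (within the scatter), lies within the scatter, so the two numbers cannot be told apart and compound 1 does not stand out from the one other measured compound. Compound 3 `COc1cc(Cl)cc(-c2nn(-c3cccc(NC(=O)Nc4ccc(Cl)c(C(F)(F)F)c4)c3)cc2-c2ccncc2)c1` has not yet been measured in this assay. It differs from compound 1 in one place: methyl in place of hydrogen on an oxygen on an aromatic ring. Going by the values given here, the only measured step, from compound 1 to compound 2, concerns a different part of the molecule, the exchange of trifluoromethyl for chloro on an aromatic carbon, and shows no change beyond the scatter; no measured step touches the hydroxy group. There is thus no direct basis in these numbers for expecting compound 3 to move in either direction, and the expectation rests on compound 1 alone. Going by these compounds, compound 3 is expected to give about -45% in this assay, between -75% and -10%, which would mean an estimated step of a number 5 percentage points higher from compound 1 to compound 3 (within the scatter), none beyond the scatter, though with a wide range since the hydroxy-to-methoxy change is untested here.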

Compound 3, a percentage reported as activity, at one concentration (the size of the read-out at that concentration, not a potency): -81%
For compound 3 the middle estimate is 36 percentage points above the measured one, and the stated range ends above it.
By their numbers in this assay, from the lowest: compound 3; then compounds 2 and 1 (each within the scatter of the next).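

In this assay, replacing hydroxy with methoxy on the 3-chloro-5-hydroxyphenyl ring is the first change among these compounds to go beyond the scatter, with a number 31 percentage points lower from compound 1 to compound 3 (beyond the scatter) and so a stronger effect at the one concentration tested. The earlier change, chloro in place of trifluoromethyl on an aromatic carbon elsewhere in the molecule, gave a number 8 percentage points lower from compound 1 to compound 2 (within the scatter) and so revealed little about how sensitive the read-out is to structure; this new step shows that adding one methyl to this oxygen can shift the result clearly, and that the hydrogen on this oxygen is not needed for the effect seen here. Nothing in the available data accounts for the size or direction of this step.

Still open, going by these compounds, is whether a longer chain on this oxygen, as in ethoxy, would shift the number further, or whether an amine or a fluorine in place of the hydroxy would act like the methoxy. On these data alone, it is also open whether the same methyl gives a similar step on compound 2, which carries chloro in place of trifluoromethyl.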